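Swapping Phenyl for a Small Acyl Group and Cytotoxicity

The compounds below may be only part of what the source reports. "The series", "measured", "known", "first", "only" and "open" are said of these compounds alone.

Compound 1 `NCCNc1cc(N2CCN(c3ccccc3)CC2)nc2ccccc12` was tested in an ADME assay on HEp-2 cells (Homo sapiens) for cytotoxicity, read by CCK-8 assay, with a stated time of 6 days (a lower number here means that less compound is tolerated, a higher number that more compound is tolerated), where compound 1 gives 20800 nM. Compound 3 `NCCNc1cc(N2CCN(c3ccccc3Cl)CC2)nc2ccccc12` gives 20800 nM, and no change at the digits printed from compound 1 to compound 3 (within the scatter). Compound 2 `CC(C)CC(=O)N1CCN(c2cc(NCCN)c3ccccc3n2)CC1` reports only a limit of the assay, > 100000 nM, rather than a number. That limit is the limit of > 100000 nM in this assay, at which 1 of the 3 values shown sits. Accordingly, an at least 4.8-fold higher number from compound 1 to compound 2 (0.68 log units; beyond the scatter). The unmeasured compound 4 `CCC(=O)N1CCN(c2cc(NCCN)c3ccccc3n2)CC1` differs from compound 1 in one place: propanoyl in place of phenyl on an amine nitrogen in a ring. The step from compound 1 to compound 2, isobutylcarbonyl in place of phenyl, is the closest measured comparison, and it went beyond the scatter toward a higher number, so a similar move is expected here. For compound 4 the estimate is 100000 nM, with a range from 40000 nM to 250000 nM. This expected change amounts to a 4.8-fold higher number from compound 1 to compound 4 (0.68 log units; beyond the scatter).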

Compound 4, half-maximal cytotoxic concentration: > 100000 nM
Compound 4 gave a limit, no number (the forecaster's own chance of this, stated with the estimate: 60%); the middle value lies on the limit itself.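

Propanoyl on this amine nitrogen in a ring gives an at least 4.8-fold higher number from compound 1 to compound 4 (0.68 log units; beyond the scatter), and in place of 2-chlorophenyl it gives an at least 4.8-fold higher number from compound 3 to compound 4 (0.68 log units; beyond the scatter). The shift seen with isobutylcarbonyl therefore also appears with a second, shorter acyl group. Compound 2 and compound 4 both end on a limit, so the step between them cannot be read: the limit of > 100000 nM in this assay, at which 2 of the 4 values shown sit.

On these data alone, how far either compound lies past that limit stays open. So does whether acetyl, benzoyl or a plain ethyl chain on this nitrogen would also reach the limit.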